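Replacing 2,4-dimethoxyphenyl with propyl: expectation for compound 3

The compounds below may be only part of what the source reports. "The series", "measured", "known", "first", "only" and "open" are said of these compounds alone.

Measured so far:
compound 1 `COc1ccc(C(c2c[nH]c3ccc(Br)cc23)c2c[nH]c3ccc(Br)cc23)c(OC)c1`: 63200 nM
compound 2 `O=[N+]([O-])c1ccc(C(c2c[nH]c3ccc(Br)cc23)c2c[nH]c3ccc(Br)cc23)cc1`: 1500 nM

In a functional assay on HeLa cells (Homo sapiens) for inhibition, read by MTT assay, with a stated time of 48 h (on this read-out lower numbers stand for stronger inhibition and higher numbers for weaker inhibition), compound 1 gives 63200 nM, the highest of the two numbers shown. Among the compounds with values here, its only neighbour is compound 2, reached by a 42-fold lower number from compound 1 to compound 2 (1.62 log units; beyond the scatter), a large change that came with 4-nitrophenyl in place of 2,4-dimethoxyphenyl on a saturated chain carbon bound to two aromatic carbons.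

Compound 3 `CCCC(c1c[nH]c2ccc(Br)cc12)c1c[nH]c2ccc(Br)cc12` differs from compound 1 by propyl in place of 2,4-dimethoxyphenyl on a saturated chain carbon bound to two aromatic carbons. The step from compound 1 to compound 2 is the only one touching this position, and it shows that the group on that carbon can move the number a great deal. Propyl, however, is neither of the two groups measured, so that step gives direction only loosely. The expected step is a 1.8-fold lower number from compound 1 to compound 3 (0.26 log units; within the scatter), a moderate drop that stays far short of what compound 2 showed. Compound 3 is therefore estimated at 35000 nM, within 8000 nM to 150000 nM.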

Compound 3, half-maximal inhibitory concentration: 3900 nM
Compound 3: middle estimate off by 9.0-fold (0.95 log units), on the high side; measured number outside the range, below it.
By their numbers in this assay, from the lowest: compound 2; then compound 3; then compound 1.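

In this assay, a ring on the saturated chain carbon bound to two aromatic carbons turns out not to be required for a low number: propyl in place of 2,4-dimethoxyphenyl gives a 16-fold lower number from compound 1 to compound 3 (1.21 log units; beyond the scatter). Set against 4-nitrophenyl, the same ringless group gives a 2.6-fold higher number from compound 2 to compound 3 (0.41 log units; beyond the scatter), so among these three groups it is 2,4-dimethoxyphenyl that stands apart, with the other two much closer together. Nothing measured here explains why these groups differ.

As far as these compounds go, whether a longer chain, an unsubstituted phenyl or an amine on this carbon would land nearer compound 2 or compound 1 remains open. The two ringed groups also differ in more than one way, so the compounds shown cannot tell whether one methoxy group alone or both go with the high number of compound 1.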